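Five-membered heteroaryl replacing a fluorophenyl on a shared core

This account rests on a few compounds, and the source may have more. Where it says the series, first, only, none or still open, it means among the compounds named here.

Measured compounds:
compound 1 `CN(Cc1ccc2nccn2c1)c1nnc(-c2ccc(-c3ccccc3F)cc2)o1`, 15.9 nM
compound 2 `Cc1nn(C)c(C)c1-c1ccc(-c2nnc(N(C)Cc3ccc4nccn4c3)o2)cc1`, 31.6 nM

Compound 1 gives 15.9 nM in an assay on isolated protein for inhibition of tyrosine-protein kinase Mer (Homo sapiens), read by LC-MS (on this read-out lower numbers stand for stronger inhibition and higher numbers for weaker inhibition), the lowest of the two numbers seen, and compound 2 sits within the scatter of it, with a 2.0-fold higher number from compound 1 to compound 2 (0.30 log units; within the scatter). Compound 3 `Cc1noc(C)c1-c1ccc(-c2nnc(N(C)Cc3ccc4nccn4c3)o2)cc1` is not yet measured in this assay. It differs from compound 1 in one place: 3,5-dimethyl-1,2-oxazol-4-yl in place of 2-fluorophenyl on an aromatic carbon. Going by the values given here, the only step that bears on this change is the one from compound 1 to compound 2, where a five-membered aromatic ring carrying methyl groups also replaced the 2-fluorophenyl and gave a 2.0-fold higher number from compound 1 to compound 2 (0.30 log units; within the scatter), a change within the scatter. On that basis the step to compound 3 is expected to be of similar size, a 1.9-fold higher number from compound 1 to compound 3 (0.28 log units; within the scatter), and not clearly beyond the scatter. Compound 3 is therefore estimated at 30 nM in this assay, with a plausible range from 12 nM to 80 nM.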

Compound 3, half-maximal inhibitory concentration: 200 nM
Compound 3: middle estimate off by 6.7-fold (0.82 log units), on the low side; measured number outside the range, above it.
By their numbers in this assay, from the lowest: compounds 1 and 2 (each within the scatter of the next); then compound 3.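

In this assay this position, para to a large group, proves sensitive to which five-membered aromatic ring enters: 3,5-dimethyl-1,2-oxazol-4-yl in place of 2-fluorophenyl gives a 13-fold higher number from compound 1 to compound 3 (1.10 log units; beyond the scatter) in contrast to the earlier step, which stayed within the scatter. Exchanging 1,3,5-trimethyl-1H-pyrazol-4-yl for 3,5-dimethyl-1,2-oxazol-4-yl gives a 6.3-fold higher number from compound 2 to compound 3 (0.80 log units; beyond the scatter) and so shows that two methyl-bearing five-membered rings of the same heavy-atom size are not interchangeable here. No measurement shown accounts for this difference.

The compounds shown leave open whether the higher number follows the ring's hetero atoms or its methyl groups, a question that an unsubstituted 1,2-oxazol-4-yl or a 1-methyl-1H-pyrazol-4-yl would address. Going by these compounds, how an amine such as piperidin-4-yl or a carboxylic acid would fare at this position also remains open.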